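The source may report more compounds than this note shows. Statements on the series, on what has been measured and on what is new or still open speak of the compounds shown alone.

Of the compounds shown here, three from one series have been tested in a functional assay on HeLa cells (Homo sapiens) for antiproliferative activity, read by MTT assay, with a stated time of 72 h; on this read-out higher numbers stand for weaker inhibition and lower numbers for stronger inhibition. Compound 1 `O=c1c(SC(=S)N2CCCCC2)coc2ccccc12` gives 9000 nM in this assay. Compound 2 `O=c1c(Cl)c(CSC(=S)N2CCCCC2)oc2ccccc12` is built on a different core; the difference between the two cores is not broken down here. In this assay, among the compounds with values here, compound 2 gives 9800 nM, a number that lies within the scatter of the one for compound 1, so the two cannot be told apart on this read-out. Compound 3 `O=c1c(Cl)c(CSC(=S)N2CCCC2)oc2ccccc12` shares the core of compound 2 and differs from it in one place: pyrrolidin-1-yl in place of piperidin-1-yl on a thiocarbonyl carbon. That single change produced a 14-fold lower number from compound 2 to compound 3 (1.15 log units; beyond the scatter), and in this assay compound 3 gives 700 nM.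

Compound 4 `O=c1c(SC(=S)N2CCCC2)coc2ccccc12` has not yet been measured. It stands to compound 1 as compound 3 stands to compound 2: pyrrolidin-1-yl in place of piperidin-1-yl on a thiocarbonyl carbon. The surroundings of the change are the same in both pairs, so this is the same change, made on the core of compound 1 rather than on the core of compound 2. The step has been seen only once, on one core, so how well it carries over is open. The expectation for compound 4 in this assay is a step of a 9.0-fold lower number from compound 1 to compound 4 (0.95 log units; beyond the scatter), which rests on the measured step of a 14-fold lower number from compound 2 to compound 3 (1.15 log units; beyond the scatter) and is given a wide band to allow for the change of core. On that basis compound 4 is estimated at 1000 nM in this assay, with a likely range from 350 nM to 4000 nM.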

Compound 4, half-maximal inhibitory concentration: 3800 nM
Compound 4: middle estimate off by 3.8-fold (0.58 log units), on the low side; the measured number falls inside the stated range.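

On the core of compound 1, pyrrolidin-1-yl in place of piperidin-1-yl on the thiocarbonyl carbon gives a 2.4-fold lower number from compound 1 to compound 4 (0.37 log units; beyond the scatter) in this assay, so the direction of the change carries over from one core to the other. The size of the step does not carry over, and the gap between the two steps is real rather than a matter of assay scatter: the same change on two cores in this assay, a 14-fold lower number (1.15 log units; beyond the scatter) from compound 2 to compound 3 and a 2.4-fold lower number (0.37 log units; beyond the scatter) from compound 1 to compound 4, 5.9-fold (0.77 log units) apart, beyond the scatter of two such steps These two pairs do not show which feature of the cores goes with the larger or the smaller step, and two cores are too few to predict the size of the step on a third.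

As far as these compounds go, it remains open how other amines on the thiocarbonyl carbon, such as azepan-1-yl, morpholin-4-yl or an open-chain dimethylamino group, would behave on either core, and whether they would show the same gap between cores. Also open, from the compounds shown here alone, is which difference between the two cores matters, a question that a core carrying only one of those differences could help to settle.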